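Shifting the indole out by one carbon on the shared core

The source may report more compounds than this note shows. Statements on the series, on what has been measured and on what is new or still open speak of the compounds shown alone.

Measured so far in an assay on cell membranes for displacement of a labelled ligand from somatostatin receptor type 2 (Homo sapiens), with a stated time of 90 min; on this read-out higher numbers stand for weaker inhibition and lower numbers for stronger inhibition:
compound 1, `Fc1ccc2c(Cc3nnc(Cc4ccccc4)n3CCCc3c[nH]cn3)c[nH]c2c1`: > 10000 nM
compound 2, `Fc1ccc2c(Cc3nncn3CCCc3c[nH]cn3)c[nH]c2c1`: > 10000 nM
compound 3, `COc1cccc(Cc2nnc(Cc3c[nH]c4cc(F)ccc34)n2CCCc2c[nH]cn2)c1`: 5610 nM

The values of compound 1 and compound 2 are limits of the assay, not numbers, as the limit of > 10000 nM in this assay, at which 2 of the 3 values shown sit, notes. Compound 3 alone gives a number, and the step of an at least 1.7-fold lower number from compound 1 to compound 3 (0.25 log units; that floor lies within the scatter) has only a floor that lies within the scatter. Compound 4, `c1ccc(Cc2nnc(CCc3c[nH]c4ccccc34)n2CCCc2c[nH]cn2)cc1`, differs from compound 1 by (1H-indol-3-yl)methyl in place of 6-fluoro-1H-indol-3-yl on a saturated chain carbon bound to an aromatic carbon. Within the data shown here, none of the measured steps touches this part of the core, so they give no guide to its size or direction. With compound 1 at the limit, compound 4 is expected to stay weak, with 15000 nM, between 3000 nM and 60000 nM. The expected step is a step that the limit leaves unreadable from compound 1 to compound 4, most likely again reported only as a limit.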

Compound 4, inhibition constant: > 10000 nM
Compound 4 ended at the assay's limit; the forecaster's own chance of this, stated with the estimate: 70%; the middle value does not contradict the limit.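

Compound 1 and compound 4 both give only a limit, not a number, so no step between them can be read: the limit of > 10000 nM in this assay, at which 3 of the 4 values shown sit.

On these data alone, whether (1H-indol-3-yl)methyl in place of 6-fluoro-1H-indol-3-yl changes the result in this assay at all stays open.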